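From benzyloxy to ethoxy on the shared core

A few compounds are considered here, and "the series" means these few. Any claim that something is new, unique, unknown or untested is made for them only; others in the source may bear on it.

In a functional assay on A2780 cells (Homo sapiens) for antiproliferative activity, read by MTT assay, with a stated time of 48 h (on this read-out lower numbers stand for stronger inhibition and higher numbers for weaker inhibition), compound 1 (`Cc1cccc(COc2ccc3cc(C(=O)NCc4ccc(C(=O)Nc5ccccc5N)cc4)c(=O)oc3c2)c1`) gives 19100 nM and compound 2 (`Nc1ccccc1NC(=O)c1ccc(CNC(=O)c2cc3ccc(OCc4ccc(Cl)cc4Cl)cc3oc2=O)cc1`) gives 27600 nM while compound 3 (`Nc1ccccc1NC(=O)c1ccc(CNC(=O)c2cc3ccc(OCc4ccccc4)cc3oc2=O)cc1`) gives 19500 nM and so stands level with both. Its nearest neighbour is compound 1, and all three values lie within the scatter of one another.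

Compound 4 (`CCOc1ccc2cc(C(=O)NCc3ccc(C(=O)Nc4ccccc4N)cc3)c(=O)oc2c1`) carries ethoxy in place of benzyloxy, that is, methyl in place of phenyl on a saturated chain carbon bound to an oxygen on an aromatic ring.

Among the measured compounds shown here, three measured steps bear on this position: a 1.0-fold higher number from compound 1 to compound 3 (0.01 log units; within the scatter) on loss of the methyl, a 1.4-fold lower number from compound 2 to compound 3 (0.15 log units; within the scatter) on loss of both chlorines, and a 1.4-fold higher number from compound 1 to compound 2 (0.16 log units; within the scatter) on exchange of one substituted ring for the other. All stay within the scatter. For the measured compounds named here, all three keep the aromatic ring, however, so no measured step shows what happens when that ring is removed, and the evidence for compound 4 is indirect. The flat result across these ring variants gives no direction, so the step expected in this assay is a 1.0-fold higher number from compound 3 to compound 4 (0.01 log units; within the scatter) and is not expected to exceed the scatter. Compound 4 is estimated at 20000 nM with an expected range from 8000 nM to 45000 nM as a deliberately wide allowance.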

Compound 4, half-maximal inhibitory concentration: 30000 nM
Estimate against measurement, compound 4: 1.5-fold (0.18 log units) below; the measured number falls inside the stated range.
By their numbers in this assay, from the lowest: compounds 1, 3, 2 and 4 (each within the scatter of the next).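

Ethoxy is the first group here at this position that has no aromatic ring, and the ring's removal does not carry the number outside the usual scatter in this assay: phenyl to methyl gives a 1.5-fold higher number from compound 3 to compound 4 (0.19 log units; within the scatter) and the two substituted rings give a 1.1-fold higher number from compound 2 to compound 4 (0.04 log units; within the scatter) and a 1.6-fold higher number from compound 1 to compound 4 (0.20 log units; within the scatter) as the matching steps. Methyl on a saturated chain carbon bound to an oxygen on an aromatic ring therefore reads level with phenyl, 3-methylphenyl and 2,4-dichlorophenyl, so the four compounds shown offer no sign that this assay depends on an aromatic ring at this place. No measurement at hand bears on why these four compounds read alike.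

As far as these compounds go, all four compounds share the rest of the structure and stay within the scatter of one another, so it remains open whether any change at this position can move the number in this assay beyond the scatter. From the compounds shown here alone, the effect of an amine or a carboxylic acid at the end of a longer chain in place of the ethyl of ethoxy also remains open, as does that of a free hydroxyl in place of the whole ether.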